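The source may report more compounds than this note shows. Statements on the series, on what has been measured and on what is new or still open speak of the compounds shown alone.

- Compound 1 `CC(C)=CCc1cc(C(=O)Nc2cc3ccc(OCCC4CCCCN4)c(C)c3oc2=O)ccc1O`: 640 nM
- Compound 2 `CC(C)=CCc1cc(C(=O)Nc2cc3ccc(OCCCNCC(C)C)c(C)c3oc2=O)ccc1O`: 1030 nM

For the measured compounds named here, in a functional assay on SK-BR-3 cells (Homo sapiens) for antiproliferative activity (a lower number here means a stronger inhibitor, a higher number a weaker inhibitor), compound 2 gives 1030 nM, which lies within the scatter of the only other measured compound, compound 1, at 640 nM. Compound 3 `CC(C)=CCc1cc(C(=O)Nc2cc3ccc(OCCCNCC(N)=O)c(C)c3oc2=O)ccc1O` keeps the shared core and differs from compound 2 in one place: carbamoyl in place of isopropyl on a saturated chain carbon bound to an amine nitrogen. Going by the values given here, only one measured step offers any guide, a 1.6-fold higher number from compound 1 to compound 2 (0.21 log units; within the scatter), and it also changes the amine-bearing chain. That step brings in no carbamoyl group, so the data do not show how this group behaves. A small step is therefore expected, probably no larger than the scatter, and the expected step is a 1.3-fold higher number from compound 2 to compound 3 (0.10 log units; within the scatter). For compound 3 the estimated value is 1300 nM, with an expected range of 500 nM to 3500 nM.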

Compound 3, half-maximal inhibitory concentration: 2290 nM
Compound 3: middle estimate off by 1.8-fold (0.25 log units), on the low side; low and high end bracket the measured number.
By their numbers in this assay, from the lowest: compounds 1 and 2 (each within the scatter of the next); then compound 3.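

In this assay, carbamoyl in place of isopropyl on a saturated chain carbon bound to an amine nitrogen gives a 2.2-fold higher number from compound 2 to compound 3 (0.35 log units; beyond the scatter) and so, unlike the earlier change in this chain, moves the number beyond the scatter. Both groups hold 3 heavy atoms, so this modest weakening comes with a swap of atom types and the gain of a hydrogen-bond donor and acceptor, not with a change in heavy-atom count, and the distance from the ring-bearing compound 1 is larger still, with a 3.6-fold higher number from compound 1 to compound 3 (0.55 log units; beyond the scatter) as the widest step in the set. No measurement on hand accounts for this weakening.

From the compounds shown here alone, whether it is specific to carbamoyl remains open, as a carboxylic acid, a hydroxyl or a primary amine at this place could give a different number. A longer chain between the amine nitrogen and the carbamoyl is equally untested by the compounds shown.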